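A Methyl on the Phenyl Ring of Compound 3

The compounds below may be only part of what the source reports. "The series", "measured", "known", "first", "only" and "open" are said of these compounds alone.

Among the compounds with values here, compound 3 `C=C1C(=O)[C@]23C[C@@]1(O)CC[C@H]2c1ccc(O)c(C)c1[C@@H]3Cn1cc(-c2ccccc2)nn1` is the only compound of this set with a number in a functional assay on SW480 cells (Homo sapiens) for cytotoxicity, read by MTT assay, with a stated time of 4 days; a higher number here means a weaker inhibitor, a lower number a stronger inhibitor: compound 3 gives 260 nM. Compound 1 `C=C1C[C@]23C[C@@]1(O)CC[C@H]2c1ccc(OS(=O)(=O)c2ccc(C)cc2)c(C)c1[C@@H]3Cn1cc(-c2ccc(Cl)cc2)nn1` reaches only the limit of the assay, > 20000 nM, in this assay. Compound 2 `Cc1c(O)ccc2c1[C@H](Cn1cc(-c3ccc(Cl)cc3)nn1)[C@@]13CC(=O)[C@@](C)(CC[C@@H]21)C3` likewise reaches only the limit > 20000 nM in this assay. So compound 3 stands alone as the one measured number, while the other two sit at the limit of > 20000 nM in this assay, at which 2 of the 3 values shown sit. Compound 4 `C=C1C(=O)[C@]23C[C@@]1(O)CC[C@H]2c1ccc(O)c(C)c1[C@@H]3Cn1cc(-c2ccc(C)cc2)nn1` differs from compound 3 by a single change: methyl in place of hydrogen on an aromatic carbon. Within the data shown here, no pair of measured compounds differs in only one place, so no measured step guides this change. The expected step of a 1.2-fold higher number from compound 3 to compound 4 (0.06 log units; within the scatter) is none beyond the usual scatter. Compound 4 is therefore expected to give about 300 nM in this assay, within a range from 100 nM to 900 nM.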

Compound 4, half-maximal inhibitory concentration: 330 nM
The estimate for compound 4 lay 1.1-fold (0.04 log units) below the measured number, within the range that was stated.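

In this assay, the change from phenyl to 4-methylphenyl gives a 1.3-fold higher number from compound 3 to compound 4 (0.10 log units; within the scatter) and so stays within the usual scatter. Within the data shown here, this is the first comparison in the set that isolates a single change, and it shows that a methyl at this place, para to a large group, leaves the number essentially unmoved. Nothing measured here explains that outcome. The compounds shown leave open whether an amine, a carboxylic acid or a longer chain on this same carbon would also leave the number unmoved.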